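The source may hold more compounds than are shown below. What is called first, only, known or untested is meant among the compounds shown, and "the series" means these compounds.

Measured in a functional assay on HCT-116 cells (Homo sapiens) for antiproliferative activity, read by MTT assay, with a stated time of 48 h; on this read-out lower numbers stand for stronger inhibition and higher numbers for weaker inhibition:
compound 1 (`COc1ccc(N(C)c2ccnc(Cl)n2)cc1O`): 422 nM
compound 2 (`COc1ccc(N(C)c2ccnc(Cl)n2)cc1OCC[Se]C#N`): 1220 nM
compound 3 (`COc1ccc(N(C)c2cc(C)nc(C)n2)cc1`): 1320 nM

Compound 3, at 1320 nM, lies within the scatter of compound 2, at 1220 nM. Both numbers stand clearly above that of compound 1, at 422 nM. The next compound to consider is compound 4 (`COc1ccc(N(C)c2cc(C)nc(C)n2)cc1O`), which departs from compound 3 in one place: hydroxy in place of hydrogen on an aromatic carbon. The new hydroxy sits ortho to a methoxy group and meta to a large group.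

Going by the values given here, no measured pair sets hydroxy directly against hydrogen, so the evidence is indirect. Among the compounds with values here, the one step that touches such a hydroxy is a 2.9-fold higher number from compound 1 to compound 2 (0.46 log units; beyond the scatter), a modest step in which the hydrogen on that oxygen is replaced by a larger group. Compound 1 also differs from compound 3 elsewhere on the shared core, so this step guides the direction only loosely. On the strength of that step, a modest move to a lower number is expected in this assay, similar in size and reversed in direction, though a result within the scatter would not surprise. The expected change is a 2.2-fold lower number from compound 3 to compound 4 (0.34 log units; beyond the scatter). The estimate for compound 4 is 600 nM, with an expected range from 180 nM to 1800 nM.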

Compound 4, half-maximal inhibitory concentration: 126 nM
Beside the measured number, compound 4's estimate is 4.8-fold (0.68 log units) above it; the measured number lies below the stated range.
By their numbers in this assay, from the lowest: compound 4; then compound 1; then compounds 2 and 3 (each within the scatter of the next).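

In this assay, going by these compounds alone, the step of a 10-fold lower number from compound 3 to compound 4 (1.02 log units; beyond the scatter) is the first direct reading of hydroxy against hydrogen on this aromatic carbon, ortho to a methoxy group, and it shows that this one added heavy atom alone is enough for a large step, where the earlier compounds offered only an indirect hint. It also agrees in direction with the modest step of a 2.9-fold higher number from compound 1 to compound 2 (0.46 log units; beyond the scatter), where a group of 5 heavy atoms takes the place of the hydrogen on that oxygen, so that in both pairs the compound with the free hydroxy holds the lower number, and neither pair goes against this, although two pairs on differing cores make only a narrow pattern. Nothing among the data shown accounts for the size of this step.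

The compounds shown leave open whether an amino group, a fluorine atom or a second methoxy group on this same aromatic carbon would give a number closer to that of compound 4 or to that of compound 3. They also leave open whether a hydroxy step of this size would hold on the chloro-bearing core of compound 1 or belongs to the methyl-bearing core of compound 4.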